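Aryl in place of methyl on the ring nitrogen

This account rests on a few compounds, and the source may have more. Where it says the series, first, only, none or still open, it means among the compounds named here.

The three measured compounds are read in a functional assay on the whole organism (Abdomen, strain Swiss albino) with Mus musculus as the target, with stated times of 10 min and 5 min, at a dose of 15 mg/kg by the oral route; a lower number here means a weaker effect, a higher number a stronger effect of the compound at the dose given. Compound 1 `CN1C(=O)C2ON=C(c3cn(-c4ccccc4)nc3-c3ccccc3)C2C1=O` gives 1.17%. Compound 3 `CN1C(=O)C2ON=C(c3cn(-c4ccccc4)nc3-c3ccc(Cl)cc3)C2C1=O` gives 7.84%; the step of a number 6.7 percentage points higher from compound 1 to compound 3 (within the scatter) is the chloro-for-hydrogen change on the aromatic carbon. Going by the values given here, compound 2 `O=C1C2ON=C(c3cn(-c4ccccc4)nc3-c3ccc(Cl)cc3)C2C(=O)N1c1ccccc1` gives 23.9%; the step of a number 16.1 percentage points lower from compound 2 to compound 3 (beyond the scatter) is the only change in this set that moves the number beyond the scatter. Compound 3 thus stands second of three numbers, close to compound 1 and clearly below compound 2.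

Compound 4 `Cc1ccc(N2C(=O)C3ON=C(c4cn(-c5ccccc5)nc4-c4ccc(Cl)cc4)C3C2=O)cc1` is not yet measured. It differs from compound 3 by 4-methylphenyl in place of methyl on an amide-type nitrogen in a ring. The step that bears on this is a number 16.1 percentage points lower from compound 2 to compound 3 (beyond the scatter), where a phenyl on the same nitrogen in place of methyl went with the higher number; the chloro step a number 6.7 percentage points higher from compound 1 to compound 3 (within the scatter) stayed within the scatter and gives no further lead. Among the compounds with values here, no measured step tells what the methyl on the entering ring adds, so the range is kept wide. For compound 4 the estimated step is a number 15.2 percentage points higher from compound 3 to compound 4 (beyond the scatter), expected to lie beyond the scatter. In this assay compound 4 is therefore expected to give 23%, with a range from 10% to 38%.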

Compound 4, a percentage reported as activity, at one dose (the size of the read-out at that dose, not a potency): 22.8%
Compound 4: the middle estimate sits 0.2 percentage points above what was measured, within the range that was stated.
By their numbers in this assay, from the lowest: compounds 1 and 3 (each within the scatter of the next); then compounds 4 and 2 (each within the scatter of the next).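

In this assay, the change from methyl to 4-methylphenyl on the amide-type nitrogen in a ring gives a number 15 percentage points higher from compound 3 to compound 4 (beyond the scatter) and is thus a second case, after the phenyl of compound 2, in which an aryl group on this nitrogen goes with the higher number. The methyl in place of hydrogen on the aromatic carbon of that phenyl gives a number 1.1 percentage points lower from compound 2 to compound 4 (within the scatter) and so separates neither compound from the other, which means that at this dose the reading does not distinguish phenyl from 4-methylphenyl on this nitrogen. Nothing at hand gives a reason for the gap between the aryl groups and methyl on this nitrogen.

Going by these compounds, both aryl groups are seen only together with the chloro group on the shared core, so whether the step from methyl to aryl holds with hydrogen in its place remains open. Also open, on these data alone, is how an amine or a carboxylic acid on the phenyl ring, or a longer chain such as butyl on the nitrogen in place of methyl, would read in this assay at this single dose.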